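A few compounds are considered here, and "the series" means these few. Any claim that something is new, unique, unknown or untested is made for them only; others in the source may bear on it.

Compound 1 `COc1cc(/C=C/c2ccc(OCCCCC(=O)NO)cc2)cc(OC)c1`: 4210 nM
Compound 2 `COc1cc(/C=C/c2ccc(OCCCCCCCC(=O)NO)cc2)cc(OC)c1`: 5050 nM

Among the compounds with values here, in a functional assay on MDA-MB-231 cells (Homo sapiens) for cytotoxicity, read by MTT assay, with a stated time of 48 h (a lower number here means a stronger inhibitor, a higher number a weaker inhibitor), compound 2 gives 5050 nM, which lies within the scatter of the only other measured compound, compound 1. Compound 3 `COc1cc(/C=C/c2ccc(OCc3ccccc3C(=O)NO)cc2)cc(OC)c1` has not yet been measured. In it, 2-(hydroxycarbamoyl)phenyl stands in place of 6-(hydroxycarbamoyl)hexyl on a saturated chain carbon bound to an oxygen on an aromatic ring: 2-(hydroxycarbamoyl)phenyl in place of 6-(hydroxycarbamoyl)hexyl on a saturated chain carbon bound to an oxygen on an aromatic ring. Within the data shown here, the one measured step, a 1.2-fold higher number from compound 1 to compound 2 (0.08 log units; within the scatter), bears on this only loosely, since it alters a saturated chain, whereas here an aromatic ring enters. Among the measured compounds shown here, no measured compound shows the effect of such a ring, so the range has to stay wide. On this slim guide, the expected step is a 1.0-fold lower number from compound 2 to compound 3 (0.00 log units; within the scatter), with no shift beyond the scatter expected in either direction. For compound 3 the estimated value is 5000 nM, with an expected range from 1700 nM to 15000 nM.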

Compound 3, half-maximal inhibitory concentration: 7180 nM
Beside the measured number, compound 3's estimate is 1.4-fold (0.16 log units) below it; the measured number falls inside the stated range.
By their numbers in this assay, from the lowest: compounds 1, 2 and 3 (each within the scatter of the next).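

In this assay, replacing the open chain of 6-(hydroxycarbamoyl)hexyl with 2-(hydroxycarbamoyl)phenyl brings a six-membered aromatic ring into this position, on a saturated chain carbon bound to an oxygen on an aromatic ring, and gives a 1.4-fold higher number from compound 2 to compound 3 (0.15 log units; within the scatter). Measured against 3-(hydroxycarbamoyl)propyl, the ring-bearing group gives a 1.7-fold higher number from compound 1 to compound 3 (0.23 log units; within the scatter), so the earlier finding on chain length now extends to a ring: neither kind of change moves the number beyond the usual scatter of this cell test. No supporting measurement explains why these three numbers stay so close.

As far as these compounds go, all three compounds carry the hydroxycarbamoyl group, so the effect of a carboxylic acid in its place remains open. Also open, from the compounds shown here alone, is whether an amine on the new ring would shift the number beyond the scatter.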